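Resorcinol-isoxazole series: swapping the pendant heterocycle

The source may hold more compounds than are shown below. What is called first, only, known or untested is meant among the compounds shown, and "the series" means these compounds.

Measured compounds
compound 1 `CCNC(=O)c1noc(-c2cc(C(C)C)c(O)cc2O)c1-c1cc(CO)no1` gives 13 nM
compound 2 `CCNC(=O)c1noc(-c2cc(C(C)C)c(O)cc2O)c1-c1cc(C(=O)OCC)no1` gives "not determined" (no result reported)
compound 3 `CCNC(=O)c1noc(-c2cc(C(C)C)c(O)cc2O)c1-c1cc(C(=O)O)no1` gives "not determined" (no result reported)

Of the three measured compounds, only compound 1 carries a number in a functional assay on HCT-116 cells (Homo sapiens) for inhibition (a higher number here means a weaker inhibitor, a lower number a stronger inhibitor), where compound 1 gives 13 nM. Compound 2 and compound 3 share the shared core of compound 1 and differ only in the group on the pendant five-membered ring, yet neither has a reported result in this assay. Compound 3 therefore stands without a number, and the same is true of compound 2, so nothing can be said of how the ester or the acid compares with the hydroxymethyl analogue.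

The next compound, compound 4 `CCNC(=O)c1noc(-c2cc(C(C)C)c(O)cc2O)c1-c1ccn(C)n1`, departs from compound 3 by the change (1-methyl-1H-pyrazol-3-yl in place of 3-carboxy-1,2-oxazol-5-yl on an aromatic carbon). Going by the values given here, no step between two measured compounds is available to anchor this change, and compound 3 itself is unmeasured. Among the compounds with values here, the only reference is compound 1, whose own pendant heterocycle is of a comparable size and also yields 13 nM. On that basis the step from compound 3 to compound 4 cannot be sized, and no direction is claimed beyond the scatter.

Compound 4 is expected to give about 25 nM in this assay, within a range of 6 nM to 100 nM.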

Compound 4, half-maximal inhibitory concentration: 16 nM
For compound 4 the middle estimate is 1.6-fold (0.19 log units) above the measured one; the range from low to high includes it.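

In this assay, going by these compounds alone, placing 1-methyl-1H-pyrazol-3-yl in the position held by 3-(hydroxymethyl)-1,2-oxazol-5-yl gives a 1.2-fold higher number from compound 1 to compound 4 (0.09 log units; within the scatter), the first step that can be read at this position on the shared core. The two pendant five-membered rings differ in their hetero atoms and substituents, and the entering group carries 0 hydrogen-bond donors, so in this one pair neither the 1,2-oxazole ring nor the hydroxyl of the hydroxymethyl group is needed to keep the number within the scatter. No supporting data bear on why the two groups read alike, and this single pair sets no rule for other groups at this position.

Steps involving the ethyl ester of compound 2 and the carboxylic acid of compound 3 cannot be read, so the reach of this position beyond compound 1 and compound 4 remains unknown. Also open, from the compounds shown here alone, is whether an aminomethyl group on the 1,2-oxazole ring, or an ethyl or longer chain in place of the methyl on the pyrazole, would stay within the scatter of these two compounds.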